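This account rests on a few compounds, and the source may have more. Where it says the series, first, only, none or still open, it means among the compounds named here.

Compound 1 `CCOC(=O)C1=C(C)NC(C)=C(C(=O)OCC)C1c1[nH]c(CC)nc1Cl` gives 0.158 nM in an assay on ileum for inhibition of Voltage-dependent L-type calcium channel subunit alpha-1C (Cavia porcellus); on this read-out higher numbers stand for weaker inhibition and lower numbers for stronger inhibition.
Compound 2 `CCc1nc(Cl)c(C2C(C(=O)OC(C)C)=C(C)NC(C)=C2C(=O)OC(C)C)[nH]1` gives 0.748 nM in this assay.

Of the two measured compounds, compound 1 has the lower number in this assay; compound 2 gives a number beyond the scatter above it, so compound 1 stands as the stronger inhibitor of the pair. Compound 3 `CCCOC(=O)C1=C(C)NC(C)=C(C(=O)OCC)C1c1[nH]c(CC)nc1Cl` has not been measured. It differs from compound 1 by methyl in place of hydrogen on a saturated chain carbon, two bonds along the chain from an oxygen next to a carbonyl group. Within the data shown here, no measured pair shows this exact change. Compounds 1 and 2 only show that enlarging both ester groups at once moves the number upward. For a single ethyl to propyl change, compound 3 is expected to stay near compound 1, with a step of a 1.6-fold higher number from compound 1 to compound 3 (0.20 log units; within the scatter) that may fall within the scatter or lean slightly upward. Compound 3 is therefore estimated at 0.25 nM, within 0.08 nM to 0.8 nM.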

Compound 3, half-maximal inhibitory concentration: 0.543 nM
The estimate for compound 3 lay 2.2-fold (0.34 log units) below the measured number; low and high end bracket the measured number.
By their numbers in this assay, from the lowest: compound 1; then compounds 3 and 2 (each within the scatter of the next).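

Lengthening a single ester group from ethoxy to propoxy does register at this position: in this assay the change alone gives a 3.4-fold higher number from compound 1 to compound 3 (0.54 log units; beyond the scatter). Among these compounds, the earlier compounds showed only a change made on both ester groups at once, so this is the first reading of one ester side by itself, and one added methyl on a saturated chain carbon, two bonds along the chain from an oxygen next to a carbonyl group, is enough to move the number beyond the scatter. The data at hand offer no explanation for this step.

The compounds shown leave open whether a longer chain such as butoxy on this side would carry the number further upward. They also leave open whether methoxy in place of the ethoxy would move it the other way.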